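Series notes: methoxy for methyl, compound 1 to compound 4

The source may report more compounds than this note shows. Statements on the series, on what has been measured and on what is new or still open speak of the compounds shown alone.

Compound 1 `Cc1cccc(Nc2nccc(-c3cccs3)n2)c1` is the reference point. In a functional assay for inhibition, with Homo sapiens as the target (a lower number here means a stronger inhibitor, a higher number a weaker inhibitor), compound 1 gives 300 nM, the lowest number of the three measured; compound 2 `Cc1ccc(-c2ccnc(Nc3cccc(N(C)C)c3)n2)s1` gives 5700 nM and compound 3 `Cc1cccc(Nc2nccc(-c3cc(C)oc3C)n2)c1` gives 28500 nM. For the measured compounds named here, the only single-point step among the measured compounds, a 95-fold higher number from compound 1 to compound 3 (1.98 log units; beyond the scatter), concerns the group on the other side of the shared core and is the largest movement in the set. Compound 2 differs from compound 1 in two places at once, so its number can only be set next to that of compound 1 without separating the two changes.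

Compound 4 `COc1cccc(Nc2nccc(-c3cccs3)n2)c1` is not yet measured. Its difference from compound 1 is methoxy in place of methyl on an aromatic carbon. Going by the values given here, no measured step touches this position on the six-membered aromatic ring of carbon only; the step from compound 1 to compound 3 sits elsewhere and gives no guide to direction here, and the two-point gap to compound 2 cannot be assigned to either of its changes. With nothing measured at this position, the expectation is a step of a 1.3-fold higher number from compound 1 to compound 4 (0.12 log units; within the scatter) in this assay, that is nothing beyond the scatter, but with a wide range. Compound 4 is accordingly estimated at 400 nM, between 100 nM and 1600 nM.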

Compound 4, half-maximal inhibitory concentration: 900 nM
For compound 4 the middle estimate is 2.3-fold (0.35 log units) below the measured one; the measured number falls inside the stated range.
By their numbers in this assay, from the lowest: compound 1; then compound 4; then compound 2; then compound 3.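

Methoxy in place of methyl gives the first measured single-point step at this position on the six-membered aromatic ring of carbon only, a 3.0-fold higher number from compound 1 to compound 4 (0.48 log units; beyond the scatter), in this assay. The position is therefore not indifferent to this change: the step lies beyond the scatter and goes towards weaker inhibition, although it is modest beside the large 95-fold higher number from compound 1 to compound 3 (1.98 log units; beyond the scatter), where 2,5-dimethylfuran-3-yl replaces thiophen-2-yl. No supporting measurement is available to explain why the number rises with this change.

The compounds shown leave open whether the step follows the added oxygen, which brings one hydrogen-bond acceptor, or the second heavy atom of methoxy, and an ethyl group or a hydroxyl group at the same place would help separate the two. They also leave open whether a chlorine atom or an unsubstituted carbon at this position would match the methyl of compound 1, and whether the methoxy step would keep its size with 2,5-dimethylfuran-3-yl in place of thiophen-2-yl.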